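Removing a lactam methyl from an inactive sulfonylamide

This account rests on a few compounds, and the source may have more. Where it says the series, first, only, none or still open, it means among the compounds named here.

Three compounds share a core built around a nitrile-bearing fused ring system joined to a saturated nitrogen ring that carries an acyl sulfonamide. Among the measured compounds shown here, compound 1 `N#Cc1cc2c(nc1N1CCC(C(=O)NS(=O)(=O)c3ccc(Cl)s3)CC1)COC2=O` is the only one with a measured number: in a functional assay (Platelet, plasma) for inhibition, with Homo sapiens as the target (a higher number here means a weaker inhibitor, a lower number a stronger inhibitor), compound 1 gives 4470 nM. Compound 2 `N#Cc1cc2c(nc1N1CCC(C(=O)NS(=O)(=O)Cc3ccccc3)C1)COC2=O` reaches only the limit of the assay, and in this assay compound 2 gives > 300000 nM. Compound 3 `CN1Cc2nc(N3CCC(C(=O)NS(=O)(=O)Cc4ccccc4)CC3)c(C#N)cc2C1=O` likewise gives only a limit, and in this assay compound 3 gives > 300000 nM. Compound 3 therefore stands at the limit of > 300000 nM in this assay, at which 2 of the 3 values shown sit, the weakest end of what the assay can report, alongside compound 2 and far from compound 1.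

The unmeasured compound 4 `N#Cc1cc2c(nc1N1CCC(C(=O)NS(=O)(=O)Cc3ccccc3)CC1)CNC2=O` differs from compound 3 in one place: hydrogen in place of methyl on an amide-type nitrogen in a ring. The benzyl sulfonyl group that compounds 2 and 3 carry stays in place. Because compound 3 sits at the limit of > 300000 nM in this assay, at which 2 of the 3 values shown sit, the step of a number no higher from compound 3 to compound 4 (the limit leaves the size open) is expected to be none beyond the scatter, and compound 4 is estimated in this assay at 300000 nM, between 60000 nM and 1000000 nM, most likely again reported as a limit.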

Compound 4, half-maximal inhibitory concentration: > 300000 nM
Compound 4: no number, only a limit; the forecaster's own chance of this, stated with the estimate: 80%; the middle value sits exactly at the limit.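

In this assay compound 4 gives > 300000 nM, which is a limit and not a number. Among the compounds shown here, compound 3 also gives only a limit, so no step between compound 3 and compound 4 can be read. The compounds shown leave open whether hydrogen in place of methyl changes inhibition at all.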